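Para-substituted hydrazones: from phenyl to chloro

The compounds below may be only part of what the source reports. "The series", "measured", "known", "first", "only" and "open" are said of these compounds alone.

Measured in an ADME assay on LL24 cells (Homo sapiens) for inhibition, read by MTT assay, with a stated time of 24 h; on this read-out lower numbers stand for stronger inhibition and higher numbers for weaker inhibition:
- compound 1 `CC(C)(C)c1ccc(C(=O)N/N=C/c2ccc([N+](=O)[O-])o2)cc1`: > 200000 nM, a limit
- compound 2 `O=C(N/N=C/c1ccc([N+](=O)[O-])o1)c1ccc(-c2ccccc2)cc1`: > 200000 nM, a limit

Compound 2 has no numerical value in this assay. Its > 200000 nM is a limit of the assay. The same holds for the only other measurement in the series, as shown by the limit of > 200000 nM in this assay, at which 2 of the 2 values shown sit.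

The next compound is compound 3 `O=C(N/N=C/c1ccc([N+](=O)[O-])o1)c1ccc(Cl)cc1`. It keeps the shared core and carries chloro in place of phenyl on an aromatic carbon.

For the measured compounds named here, only one measured step bears on this change, because a step that the two limits leave unreadable from compound 1 to compound 2 involves a replacement at the same carbon. Its size cannot be read, so it offers no magnitude or direction to carry over. With tert-butyl and phenyl both at the limit in compound 1 and compound 2, no step beyond the scatter is expected in this assay, and no direction is favoured. The expected change is a number no higher from compound 2 to compound 3 (the limit leaves the size open). A report as a limit is the most likely outcome for the next measurement. For compound 3 the estimated value is 200000 nM, with an expected range from 80000 nM to 400000 nM.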

Compound 3, half-maximal inhibitory concentration: 187000 nM
Compound 3: middle estimate off by 1.1-fold (0.03 log units), on the high side, and the stated range covers the measured number.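

In this assay, for the compounds shown here, compound 3 gives 187000 nM, the first true number at this position, on an aromatic carbon para to a large group. Chloro in place of phenyl gives an at least 1.0-fold lower number from compound 2 to compound 3 (0.02 log units; that floor lies within the scatter), and chloro in place of tert-butyl gives an at least 1.0-fold lower number from compound 1 to compound 3 (0.02 log units; that floor lies within the scatter). Neither floor goes beyond the scatter, so chloro brings a readable value but no demonstrated gain over the other two groups, and most of the series still sits at the limit: the limit of > 200000 nM in this assay, at which 2 of the 3 values shown sit.

As far as these compounds go, the true values of compound 1 and compound 2 remain unknown, which leaves the real size of both steps open. Also open, from the compounds shown here alone, is whether an amine, a carboxylic acid or a methoxy group at the same carbon would give a number clearly beyond the scatter from compound 3.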